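A few compounds are considered here, and "the series" means these few. Any claim that something is new, unique, unknown or untested is made for them only; others in the source may bear on it.

Compound 1 `Nc1ncnn2c([C@@H]3O[C@H](CO)[C@@H](O)[C@H]3O)ccc12` and compound 2 `C[C@@]1(c2ccc3c(N)ncnn23)O[C@H](CO)[C@@H](O)[C@H]1O` share a core and differ at one saturated ring carbon. In an ADME assay on Huh-7 cells (Homo sapiens) for cytotoxicity, read by fluorescence, with a stated time of 3 days (on this read-out higher numbers stand for lower toxicity in this test and lower numbers for higher toxicity in this test), compound 1 gives 150 nM, while in this assay compound 2 gives 62000 nM, the higher of the two numbers and far beyond the scatter from compound 1. Compound 3 `C#C[C@@]1(c2ccc3c(N)ncnn23)O[C@H](CO)[C@@H](O)[C@H]1O` carries ethynyl in place of methyl on a saturated ring carbon. Going by the values given here, no comparable pair has been measured, so the step is uncertain; compound 3 is expected to stay closer to compound 2 than to compound 1, with a step of a 2.1-fold lower number from compound 2 to compound 3 (0.32 log units; beyond the scatter). Compound 3 is estimated at 30000 nM, within 5000 nM to 100000 nM.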

Compound 3, half-maximal cytotoxic concentration: > 88000 nM
Compound 3: a limit, no number (the forecaster's own chance of this, stated with the estimate: 30%); at least 2.9-fold (0.46 log units) between middle value and limit.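

In this assay, ethynyl in place of methyl on this saturated ring carbon gives an at least 1.4-fold higher number from compound 2 to compound 3 (0.15 log units; that floor lies within the scatter), so a second carbon atom in this group does not bring the number back down to the level at which compound 1 gives 150 nM in this test. The result for compound 3 is a limit and not a number: the limit of > 88000 nM in this assay, at which 1 of the 3 values shown sits. How much lower the toxicity of compound 3 is in this test therefore stays unresolved. Still open, going by these compounds, is whether a nitrile, an amine or a longer chain at this ring carbon would also keep the number high.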